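Replacing the pyridinyl group with cyclopropyl on the amine

A few compounds are considered here, and "the series" means these few. Any claim that something is new, unique, unknown or untested is made for them only; others in the source may bear on it.

Of the compounds shown here, three sharing one core have been measured in a physicochemical assay for lipophilicity, read by HPLC; on this read-out higher numbers stand for higher lipophilicity and lower numbers for lower lipophilicity. Compound 1 `CC(=O)NC[C@H]1CN(c2ccc(OC[C@@H](O)CNc3ccccn3)c(F)c2)C(=O)O1` gives 1.37, and compound 2 `CC(=O)NC[C@H]1CN(c2ccc(OC[C@H](O)CNc3ccccn3)c(F)c2)C(=O)O1` gives 1.6; the step of a number 0.23 log units higher from compound 1 to compound 2 (within the scatter) is within the scatter, which fits (the fact that compounds 1 and 2 differ only in the configuration as drawn). Compound 3 `CC(=O)NC[C@H]1CN(c2ccc(OC[C@@H](O)CNc3ccncc3)c(F)c2)C(=O)O1` gives -0.04, the lowest of the three numbers; the step of a number 1.41 log units lower from compound 1 to compound 3 (beyond the scatter) and the step of a number 1.64 log units lower from compound 2 to compound 3 (beyond the scatter) are both large drops that came with pyridin-4-yl in place of pyridin-2-yl on the amine nitrogen.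

Compound 4 `CC(=O)NC[C@H]1CN(c2ccc(OC[C@@H](O)CNC3CC3)c(F)c2)C(=O)O1` is not yet measured. It differs from compound 3 by cyclopropyl in place of pyridin-4-yl on an amine nitrogen. Going by the values given here, none of the measured steps covers a change from a pyridinyl group to cyclopropyl on that nitrogen, so the expectation for compound 4 rests on the value of compound 3 alone, and the step of a number 0.04 log units higher from compound 3 to compound 4 (within the scatter) is expected to stay within the scatter. Compound 4 is therefore estimated to give 0, with a range from -0.8 to 0.8 in this assay.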

Compound 4, partition coefficient: 0.02
Compound 4: middle estimate off by 0.02 log units, on the low side; the range from low to high includes it.
By their numbers in this assay, from the lowest: compounds 3 and 4 (each within the scatter of the next); then compounds 1 and 2 (each within the scatter of the next).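

At this amine nitrogen, the aromatic, nitrogen-bearing ring of pyridin-4-yl and the all-carbon ring of cyclopropyl cannot be told apart in this assay, with a number 0.06 log units higher from compound 3 to compound 4 (within the scatter). Cyclopropyl in place of pyridin-2-yl gives a number 1.35 log units lower from compound 1 to compound 4 (beyond the scatter), and the listed step from the other drawn configuration, which also changes that stereocentre, gives a number 1.58 log units lower from compound 2 to compound 4 (beyond the scatter), so among these compounds only the two carrying pyridin-2-yl, compound 1 and compound 2, stand apart at the higher numbers. Nothing available here explains why these groups sort this way.

From the compounds shown here alone, it remains open where other groups on this nitrogen would fall, such as pyridin-3-yl, phenyl or a longer alkyl chain. Going by these compounds, it is also open whether cyclopropyl with the opposite configuration at the hydroxyl-bearing chain carbon would stay within the scatter of compound 4.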